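This account rests on a few compounds, and the source may have more. Where it says the series, first, only, none or still open, it means among the compounds named here.

Measured in a functional assay on HEK293 cells for agonist activity at Bombesin receptor subtype-3 (Homo sapiens), read by luminescence and calcium flux, with a stated time of 10 min; a lower number here means that less compound is needed, a higher number that more compound is needed for the effect:

Compound 1 `CCC(C)(C)Cc1c[nH]c(CCc2ccc(-c3ccncc3)cc2)n1`: 95 nM
Compound 2 `CCC(C)(C)Cc1c[nH]c(CCc2ccc(-c3ccccc3C(=O)O)cc2)n1`: 101 nM
Compound 3 `CCC(C)(C)Cc1c[nH]c(CCc2ccc(-c3cnsc3)cc2)n1`: 100 nM

Compound 3 stands second highest of the three numbers, but the steps that lead to it, a 1.1-fold higher number from compound 1 to compound 3 (0.02 log units; within the scatter) and a 1.0-fold lower number from compound 2 to compound 3 (0.00 log units; within the scatter), both lie within the scatter, so the three compounds cannot be told apart in this assay.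

Compound 4 `CCC(C)(C)Cc1c[nH]c(CCc2ccc(-c3cccnc3)cc2)n1` differs from compound 3 in one place: pyridin-3-yl in place of 1,2-thiazol-4-yl on an aromatic carbon. Within the data shown here, the steps that bear on this exchange of one aromatic ring for another at the same place are a 1.1-fold higher number from compound 1 to compound 3 (0.02 log units; within the scatter) and a 1.0-fold lower number from compound 2 to compound 3 (0.00 log units; within the scatter), both within the scatter; three different rings there gave essentially the same number. A step beyond the scatter is therefore not expected, and the estimated step is no change at the digits printed from compound 3 to compound 4 (within the scatter). Compound 4 is expected to give 100 nM, with a range from 40 nM to 250 nM.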

Compound 4, half-maximal effective concentration: 98 nM
The estimate for compound 4 lay 1.0-fold (0.01 log units) above the measured number, and the stated range covers the measured number.
By their numbers in this assay, from the lowest: compounds 1, 4, 3 and 2 (each within the scatter of the next).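

In this assay the change from one pyridine attachment to the other leaves no readable difference: pyridin-3-yl in place of pyridin-4-yl gives (a 1.0-fold higher number from compound 1 to compound 4 (0.01 log units; within the scatter)). The pyridin-3-yl ring also matches 1,2-thiazol-4-yl (a 1.0-fold lower number from compound 3 to compound 4 (0.01 log units; within the scatter)) and 2-carboxyphenyl (a 1.0-fold lower number from compound 2 to compound 4 (0.01 log units; within the scatter)), so all four aromatic rings at this place, para to a large group, give numbers that cannot be told apart. No measured evidence accounts for this flat result.

On these data alone, whether a non-aromatic group here, such as a piperidine, a primary amine or a short alkyl chain, would shift the number remains open. Changes elsewhere on the shared core also remain open.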